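Butyl on the piperazine nitrogen: a step in cytotoxicity

The source may hold more compounds than are shown below. What is called first, only, known or untested is meant among the compounds shown, and "the series" means these compounds.

Measured compounds:
- compound 1 `CN1CCN(CCCCCCn2c3c(c4ccccc42)C(=O)c2c[n+]([O-])c4ccccc4c2C3=O)CC1`: 3800 nM
- compound 2 `O=C1c2c[n+]([O-])c3ccccc3c2C(=O)c2c1c1ccccc1n2Cc1cn(C[C@@H](O)CO)nn1`: 490 nM
- compound 3 `O=C1c2c[n+]([O-])c3ccccc3c2C(=O)c2c1c1ccccc1n2CCCCN1CCNCC1`: 1380 nM

Of the compounds shown here, three sharing one core have been tested in a toxicity assay on L02 cells (Homo sapiens) for cytotoxicity, read by MTT assay, with a stated time of 72 h; a higher number here means a weaker inhibitor, a lower number a stronger inhibitor. Compound 3 sits second highest of the three numbers; its nearest neighbour is compound 1, with a 2.8-fold lower number from compound 1 to compound 3 (0.44 log units; beyond the scatter), and the furthest is compound 2, with a 2.8-fold higher number from compound 2 to compound 3 (0.45 log units; beyond the scatter). Compound 4 `CCCCN1CCN(CCCCn2c3c(c4ccccc42)C(=O)c2c[n+]([O-])c4ccccc4c2C3=O)CC1` has not yet been measured. It differs from compound 3 in one place: butyl in place of hydrogen on an amine nitrogen in a ring.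

Within the data shown here, no measured step changes only this position. The closest guide is the step from compound 1 to compound 3, a 2.8-fold lower number from compound 1 to compound 3 (0.44 log units; beyond the scatter), where a methyl on the ring nitrogen and two chain carbons are lost together and the number falls modestly. Compound 4 adds a butyl at that ring nitrogen while keeping the chain of compound 3, so it moves partly back toward compound 1. The step in this assay is therefore expected to be small, most likely toward a higher number, and may stay within the scatter.

For compound 4 the estimated value in this assay is 2500 nM, with an expected range from 1000 nM to 6000 nM, corresponding to an expected step of a 1.8-fold higher number from compound 3 to compound 4 (0.26 log units; within the scatter).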

Compound 4, half-maximal inhibitory concentration: 5690 nM
The estimate for compound 4 lay 2.3-fold (0.36 log units) below the measured number; measured number inside the range.
By their numbers in this assay, from the lowest: compound 2; then compound 3; then compounds 1 and 4 (each within the scatter of the next).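

In this assay, among these compounds, this is the first step that changes only the amine nitrogen in the ring: with the chain of compound 3 kept, butyl in place of hydrogen gives a 4.1-fold higher number from compound 3 to compound 4 (0.62 log units; beyond the scatter), so this one position can by itself move the number beyond the scatter. Compound 1 carries a methyl on that ring nitrogen and a different chain, and the listed step to the butyl compound is a 1.5-fold higher number from compound 1 to compound 4 (0.18 log units; within the scatter), so these two different combinations of ring substituent and chain read alike here. Nothing on hand explains why butyl has this effect.

The compounds shown give a single substituent at this nitrogen on the chain of compound 3, so they leave open whether the number rises step by step with substituent length, which an ethyl or a hexyl group there would test. They also leave open how a group of another kind, such as an acetyl group or a carboxylic acid attached through a short chain, would read at the same nitrogen.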